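The compounds below may be only part of what the source reports. "The series", "measured", "known", "first", "only" and "open" are said of these compounds alone.

Compound 1 `C=CCn1c(SCC(=O)Nc2ccc(C(C)=O)cc2)nnc1-c1ccccc1`: 70%
Compound 2 `C=CCn1c(SCC(=O)Nc2ccc(/C(C)=N/O)cc2)nnc1-c1ccccc1`: 73%
Compound 3 `C=CCn1c(SCC(=O)Nc2ccc(C(C)=O)cc2)nnc1-c1ccc(OC)c(OC)c1`: 70%

Three compounds of one series were tested in a functional assay on the whole organism (strain albino) for inhibition, with Rattus norvegicus as the target, read by paw edema, with stated times of 30 min and 4 h, at a dose of 0.28 mmol/kg by the oral route; a higher number here means more inhibition at the dose given (going by the name of the read-out), a lower number less inhibition. Compound 1 gives 70% there, compound 2 gives 73% and compound 3 gives 70%. Compound 1 and compound 2 share a core and differ by a group of 4 heavy atoms (2 carbon, 1 nitrogen, 1 oxygen; no ring) in place of a group of 3 heavy atoms (2 carbon, 1 oxygen; no ring), on an aromatic carbon; that change made a step of a number 3 percentage points higher from compound 1 to compound 2 (within the scatter). The core of compound 3 differs from the core of compound 1 by 3,4-dimethoxyphenyl in place of phenyl on an aromatic carbon, and that step was no change at the digits printed from compound 1 to compound 3 (within the scatter), so compound 1 and compound 3 stand level in this assay.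

Compound 4 `C=CCn1c(SCC(=O)Nc2ccc(/C(C)=N/O)cc2)nnc1-c1ccc(OC)c(OC)c1` has not yet been measured. It stands to compound 3 as compound 2 stands to compound 1, carrying (a group of 4 heavy atoms (2 carbon, 1 nitrogen, 1 oxygen; no ring) in place of a group of 3 heavy atoms (2 carbon, 1 oxygen; no ring), on an aromatic carbon); the place of the change is the same in both pairs, so this is the same change made on the other core. Since compound 3 sits at 70% and the step from compound 1 to compound 2 was a number 3 percentage points higher from compound 1 to compound 2 (within the scatter), compound 4 is expected to show a step of a number 3 percentage points higher from compound 3 to compound 4 (within the scatter). Compound 4 is therefore estimated at 73%, expected to lie between 62% and 84%.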

Compound 4, a percentage reported as inhibition, in the whole organism at one dose (the size of the read-out at that dose, not a potency): 79%
Compound 4: the middle estimate sits 6 percentage points below what was measured, and the stated range covers the measured number.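

In this assay, putting the new group in place of acetyl on the core of compound 3 gave a number 9 percentage points higher from compound 3 to compound 4 (within the scatter), and this step cannot be told apart from the one seen on the core of compound 1: the same change on two cores in this assay, a number 3 percentage points higher (within the scatter) from compound 1 to compound 2 and a number 9 percentage points higher (within the scatter) from compound 3 to compound 4, 6 percentage points apart, within the scatter of two such steps

Read the other way, 3,4-dimethoxyphenyl in place of phenyl gave a number 6 percentage points higher from compound 2 to compound 4 (within the scatter), and this step likewise agrees with its earlier counterpart: the same change on two cores in this assay, no change at the digits printed (within the scatter) from compound 1 to compound 3 and a number 6 percentage points higher (within the scatter) from compound 2 to compound 4, 6 percentage points apart, within the scatter of two such steps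

Each change therefore carried from one core to the other without a detectable difference in step, but every step among these compounds lies within the scatter, so they do not show that either change has an effect of its own, or that the two changes act together, and two cores say little about the wider series.

As far as these compounds go, whether a carboxylic acid or an amine in place of acetyl would give a step beyond the scatter remains open. Also open is how these compounds would compare at other doses, as only one dose is shown.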